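The compounds below may be only part of what the source reports. "The series", "measured", "known", "first", "only" and "open" are said of these compounds alone.

Measured compounds:
compound 1, `Cc1ccc(-c2nn(-c3cccc(Cl)c3)cc2C(=O)Nc2ccc(C)c(S(=O)(=O)N3CCOCC3)c2)cc1`, 5910 nM
compound 2, `COc1cccc(Cn2cc(C(=O)Nc3ccc(C)c(S(=O)(=O)N4CCOCC4)c3)c(C(C)C)n2)c1`, 3110 nM
compound 3, `COCCc1nn(Cc2cccc(OC)c2)cc1C(=O)Nc1ccc(C)c(S(=O)(=O)N2CCOCC2)c1`, 11100 nM

In an assay on HEK-293T cells for inhibition of Bile acid receptor (Homo sapiens), read by a beta-lactamase reporter, with a stated time of 16 h (a lower number here means a stronger inhibitor, a higher number a weaker inhibitor), compound 1 gives 5910 nM. Its number lies within the usual scatter of both compound 2 and compound 3, so on these three values compound 1 neither stands apart as stronger nor as weaker; the three compounds sit close together as weak inhibitors.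

Compound 4, `Cc1ccc(-c2nn(-c3ccccc3)cc2C(=O)Nc2ccc(C)c(S(=O)(=O)N3CCOCC3)c2)cc1`, has not yet been measured. It is made from compound 1 by a single change: hydrogen in place of chloro on an aromatic carbon.

Among the compounds with values here, the only measured step between neighbouring compounds is a 3.6-fold higher number from compound 2 to compound 3 (0.55 log units; beyond the scatter). That step alters a group on the shared core and not the ring that is changed here, so it does not speak directly to the chloro-to-hydrogen swap. Within the data shown here, no measured pair shows what removing chloro from this ring does. With nothing pointing one way, the step is expected to stay within the scatter, a 1.2-fold higher number from compound 1 to compound 4 (0.07 log units; within the scatter), and the estimate for compound 4 in this assay is 7000 nM, with a range from 2500 nM to 20000 nM.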

Compound 4, half-maximal inhibitory concentration: 2620 nM
For compound 4 the middle estimate is 2.7-fold (0.43 log units) above the measured one; the measured number falls inside the stated range.
By their numbers in this assay, from the lowest: compounds 4, 2, 1 and 3 (each within the scatter of the next, the first and the last beyond it).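

In this assay, going from 3-chlorophenyl to phenyl gives a step of a 2.3-fold lower number from compound 1 to compound 4 (0.35 log units; beyond the scatter), so this place on the ring does respond to what it carries, and here the inhibitor holds up better without the chloro. Within the data shown here, this is the first measured change on this ring, since the earlier step concerned a different group on the shared core, though the step is modest and compound 4 is still a weak inhibitor at 2620 nM. Nothing measured here explains the step.

The compounds shown compare only chloro and hydrogen at this place, so it stays open how a fluoro, a methoxy or an amine there would read. Also open, from the compounds shown here alone, is whether removing chloro would give a step of similar size with an isopropyl group elsewhere on the shared core, as in compound 2.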